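The compounds below may be only part of what the source reports. "The series", "measured", "known", "first", "only" and "open" are said of these compounds alone.

Of the compounds shown here, three sharing one core have been measured in a functional assay on HeLa cells (Homo sapiens) for inhibition, read by CCK-8 assay, with a stated time of 48 h; on this read-out higher numbers stand for weaker inhibition and lower numbers for stronger inhibition: compound 1 `COc1cc(-c2ccnc3cc(-c4ccc(F)cc4)nn23)cc(OC)c1OC` gives 5840 nM, compound 2 `COc1cc(-c2ccnc3cc(-c4ccc(N(C)C)cc4)nn23)cc(OC)c1OC` gives 378 nM, and compound 3 `COc1cc(-c2ccnc3cc(-c4ccc5cnn(C)c5c4)nn23)cc(OC)c1OC` gives 97 nM. Compound 2 therefore stands in the middle of the three. Compound 4 `CCOC(=O)c1ccc(-c2cc3nccc(-c4cc(OC)c(OC)c(OC)c4)n3n2)cc1` carries ethoxycarbonyl in place of dimethylamino on an aromatic carbon, para to a large group: ethoxycarbonyl in place of dimethylamino on an aromatic carbon. Among the measured compounds shown here, the closest precedent is dimethylamino in place of fluoro, a large step, a 15-fold lower number from compound 1 to compound 2 (1.19 log units; beyond the scatter). The change to 1-methyl-1H-indazol-6-yl, a 3.9-fold lower number from compound 2 to compound 3 (0.59 log units; beyond the scatter), is modest and bears less directly. For the measured compounds named here, no compound measured so far carries ethoxycarbonyl, so the comparison is indirect. With compound 1 as the guide, a large step toward a higher number is expected in this assay, namely a 6.6-fold higher number from compound 2 to compound 4 (0.82 log units; beyond the scatter). Compound 4 is estimated at 2500 nM, within a range of 700 nM to 9000 nM.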

Compound 4, half-maximal inhibitory concentration: > 10000 nM
Compound 4: only a limit was reported; the forecaster's own chance of this, stated with the estimate: 5%; middle value at least 4.0-fold (0.60 log units) from the limit.
By their numbers in this assay, from the lowest: compound 3; then compound 2; then compound 1. At a limit, above all of these: compound 4.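

Compound 4 gives a limit of the assay, not a number, in this assay: the limit of > 10000 nM in this assay, at which 1 of the 4 values shown sits. Ethoxycarbonyl in place of dimethylamino on this aromatic carbon, para to a large group, still gives an at least 26-fold higher number from compound 2 to compound 4 (1.42 log units; beyond the scatter), so this position can also move the number sharply upward, whereas the earlier steps all ran downward. Against fluoro, the change gives an at least 1.7-fold higher number from compound 1 to compound 4 (0.23 log units; that floor lies within the scatter), and as that floor lies within the scatter, no order between those two groups can be stated. Going by these compounds, how far compound 4 lies past its limit remains open. So does whether a carboxylic acid or a primary amide at this position would stay near compound 4 or come closer to compound 2.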